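Isopropylamino Replaced by 2-Aminoethyl on the Shared Core

The compounds below may be only part of what the source reports. "The series", "measured", "known", "first", "only" and "open" are said of these compounds alone.

compound 1 `CC(C)NCc1nnc(-c2ccccc2-c2ccccc2)s1`: 23 mg/kg in a functional assay on the whole organism with Mus musculus as the target; on this read-out higher numbers stand for an effect only at larger amounts of compound and lower numbers for an effect already at smaller amounts
compound 2 `NCc1nnc(-c2ccccc2-c2ccccc2)s1`: 20 mg/kg in this assay

Compound 1 and compound 2 sit within the scatter of each other: a 1.2-fold lower number from compound 1 to compound 2 (0.06 log units; within the scatter). Compound 3 `NCCCc1nnc(-c2ccccc2-c2ccccc2)s1` differs from compound 1 by 2-aminoethyl in place of isopropylamino on a saturated chain carbon bound to an aromatic carbon. Within the data shown here, the one measured step bears only loosely on this change, as it removes the isopropyl without lengthening the chain; no measured pair covers chain extension. Given that a 1.2-fold lower number from compound 1 to compound 2 (0.06 log units; within the scatter) was within the scatter, the expected step in this assay is a 1.0-fold lower number from compound 1 to compound 3 (0.02 log units; within the scatter), with no change beyond the scatter anticipated. Compound 3 is estimated at 22 mg/kg, range 10 mg/kg to 50 mg/kg.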

Compound 3, dose for half-maximal effect: > 200 mg/kg
Compound 3 was reported as a limit; the forecaster's own chance of this, stated with the estimate: 10%; middle value at least 9.0-fold (0.95 log units) from the limit.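

Compound 3 is read as a limit of the assay and not as a number: the limit of > 200 mg/kg in this assay, at which 1 of the 3 values shown sits. Swapping isopropylamino for 2-aminoethyl gives an at least 8.6-fold higher number from compound 1 to compound 3 (0.93 log units; beyond the scatter), and swapping amino for 2-aminoethyl gives an at least 10-fold higher number from compound 2 to compound 3 (1.00 log units; beyond the scatter), both beyond the scatter. Removing the isopropyl alone stayed within the scatter, so this position responds to the 3-aminopropyl chain in a way the nitrogen substituent step did not reveal.

A 2-aminoethyl chain on the shared core would show where along the chain the number rises. On these data alone, an isopropyl group on the amine of the 3-aminopropyl chain remains open too.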